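The source may report more compounds than this note shows. Statements on the series, on what has been measured and on what is new or still open speak of the compounds shown alone.

Measured so far in an ADME assay on L6 cells (Rattus norvegicus) for cytotoxicity; a higher number here means a weaker inhibitor, a lower number a stronger inhibitor:
compound 1 `O=C(NCCCN1CCN(CCCNc2ccnc3cc(Cl)ccc23)CC1)c1cccc(OC(F)(F)F)c1`, 8500 nM
compound 2 `O=C(NCCCN1CCN(CCCNc2ccnc3cc(Cl)ccc23)CC1)c1ccccc1C(=O)c1ccccc1`, 3200 nM

Compound 1 stands highest of the two numbers in this assay; compound 2 sits below it, and that gap lies beyond the usual scatter. No single-point step joins these two compounds, so only their two values are shown. Compound 3 `O=C(CCCOc1ccccc1)NCCCN1CCN(CCCNc2ccnc3cc(Cl)ccc23)CC1` is not yet measured; it differs from compound 1 by 3-phenoxypropyl in place of 3-(trifluoromethoxy)phenyl on a carbonyl carbon. Going by the values given here, with no measured step of this kind, the expected shift in this assay is a 1.4-fold lower number from compound 1 to compound 3 (0.15 log units; within the scatter), small and toward a lower number if any. Compound 3 is estimated at 6000 nM, with a range from 2500 nM to 15000 nM.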

Compound 3, half-maximal inhibitory concentration: 9300 nM
Compound 3: the middle estimate sits 1.6-fold (0.19 log units) below what was measured; measured number inside the range.
By their numbers in this assay, from the lowest: compound 2; then compounds 1 and 3 (each within the scatter of the next).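

On a carbonyl carbon whose other neighbour is an amide-type nitrogen, 3-phenoxypropyl in place of 3-(trifluoromethoxy)phenyl gives a 1.1-fold higher number from compound 1 to compound 3 (0.04 log units; within the scatter) in this assay. At this position, then, an aromatic ring carried on a chain and a fluorine-bearing aromatic ring give values within the scatter of each other in this read-out. No supporting measurement bears on this result.

Open, as far as these compounds go, is whether an amine or a carboxylic acid in place of 3-phenoxypropyl on this carbonyl carbon would shift the number beyond the scatter. From the compounds shown here alone, a longer chain at the same place also remains open.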